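Ring size of the amine in a quinoline-type core series

The compounds below may be only part of what the source reports. "The series", "measured", "known", "first", "only" and "open" are said of these compounds alone.

Measured compounds:
compound 1 `COc1cc2nc(-c3ccc(C(F)(F)F)cc3)cc(OCCCN3CCCC3)c2cc1OC` — 0%
compound 2 `COc1cc2nc(-c3ccc(Cl)cc3)cc(OCCCN3CCCC3)c2cc1OC` — 20%

In an assay on isolated protein for inhibition of DNA topoisomerase 1 (Homo sapiens), with a stated time of 30 min, tested at 1 uM (a lower number here means less inhibition, a higher number more inhibition at the concentration tested (going by the name of the read-out)), compound 1 gives the lower of the two numbers; compound 2 sits a number 20 percentage points higher from compound 1 to compound 2 (beyond the scatter), a change in the aryl group rather than in the amine. Compound 3 `COc1cc2nc(-c3ccc(C(F)(F)F)cc3)cc(OCCCN3CCCCC3)c2cc1OC` carries piperidin-1-yl in place of pyrrolidin-1-yl on a saturated chain carbon, three bonds along the chain from an oxygen on an aromatic ring. No measured step touches this amine ring, so nothing shown bears on it, and no step beyond the scatter is expected in this assay. Compound 3 is therefore estimated at 5% (range 0% to 20%), a step of a number 5 percentage points higher from compound 1 to compound 3 (within the scatter) being expected.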

Compound 3, a percentage reported as inhibition, at one concentration (the size of the read-out at that concentration, not a potency): 20%
Estimate against measurement, compound 3: 15 percentage points below, within the range that was stated.
By their numbers in this assay, from the lowest: compound 1; then compounds 2 and 3 (each within the scatter of the next).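

In this assay the change to piperidin-1-yl gives a number 20 percentage points higher from compound 1 to compound 3 (beyond the scatter) and so shows that the amine ring, not only the aryl group, is a place where this read-out moves. The step was read with the trifluoromethyl group held fixed, on a saturated chain carbon, three bonds along the chain from an oxygen on an aromatic ring. Nothing measured here accounts for this step.

As far as these compounds go, whether it would also hold with the chloro group of compound 2 remains open. So does what a morpholine ring, an azepane ring or a longer chain would give here.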